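The source may report more compounds than this note shows. Statements on the series, on what has been measured and on what is new or still open speak of the compounds shown alone.

For the measured compounds named here, in a functional assay on A549 cells (Homo sapiens) for inhibition, read by MTT assay, with a stated time of 48 h (a higher number here means a weaker inhibitor, a lower number a stronger inhibitor), compound 1 `O=C(Nc1cc(-c2cccnc2)cc(C(F)(F)F)c1)Nc1nccs1` gives 92100 nM as the only number so far. Compound 2 `COc1ccc(-c2cc(NC(=O)Nc3nccs3)cc(C(F)(F)F)c2)cn1` stands at "not determined" (no result reported) in this assay and so has no place on the scale, and no step can be read from it. Going on to compound 3 `O=C(Nc1cc(-c2cncnc2)cc(C(F)(F)F)c1)Nc1nccs1` puts pyrimidin-5-yl in place of 6-methoxypyridin-3-yl on an aromatic carbon, with the rest of the structure unchanged, as counted here: pyrimidin-5-yl in place of 6-methoxypyridin-3-yl on an aromatic carbon. Going by the values given here, no measured step is available to guide the size of this change. Among the compounds with values here, the sole reference is compound 1 at 92100 nM in this assay and no shift beyond the usual scatter from that level is expected, in either direction. For compound 3 the expected value is 80000 nM with an estimated range from 30000 nM to 200000 nM in this weak region.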

Compound 3, half-maximal inhibitory concentration: 18300 nM
Beside the measured number, compound 3's estimate is 4.4-fold (0.64 log units) above it, outside the stated range (below it).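

In this assay, for the compounds shown here, the position meta to the trifluoromethyl group proves sensitive to the ring it carries: pyrimidin-5-yl in place of pyridin-3-yl gives a 5.0-fold lower number from compound 1 to compound 3 (0.70 log units; beyond the scatter), the first measured step and one that lies beyond the scatter. Steps involving compound 2 cannot be read, as compound 2 has no reported number, so the effect of the 6-methoxypyridin-3-yl group remains unplaced on this scale. No measurement available here accounts for the step.

The compounds shown leave open how this position responds to a group other than a six-membered aromatic ring, such as an amine, a carboxylic acid or a longer chain. Also open, from the compounds shown here alone, is whether the same ring exchange gives a step of similar size when the trifluoromethyl group is replaced by a nitrile.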